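This account rests on a few compounds, and the source may have more. Where it says the series, first, only, none or still open, it means among the compounds named here.

Measured so far in an ADME assay on HepG2 cells (Homo sapiens) for cytotoxicity, read by MTT assay, with a stated time of 72 h (a higher number here means that more compound is tolerated, a lower number that less compound is tolerated), as limits, with one compound still open:
Compound 1 `O=[N+]([O-])c1c(CS(=O)(=O)c2ccccc2)nc2c(-c3ccccc3)cc(Cl)cn12` gives > 15600 nM as a limit
Compound 2 `O=[N+]([O-])c1c(CS(=O)(=O)c2ccccc2)nc2c(-c3ccc(O)cc3)cc(Cl)cn12` gives > 12500 nM as a limit
Compound 3 `O=[N+]([O-])c1c(CS(=O)(=O)c2ccccc2)nc2c(-c3cccc(CO)c3)cc(Cl)cn12` gives > 25000 nM as a limit
Compound 4 `O=[N+]([O-])c1c(CS(=O)(=O)c2ccccc2)nc2c(-c3cccc(F)c3)cc(Cl)cn12` is not yet measured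

Compound 3 stands at > 25000 nM in this assay and this is a limit, not a number. The other two measured compounds are also reported only as limits, so the three cannot be ranked. Compound 4 differs from compound 3 by fluoro in place of hydroxymethyl on an aromatic carbon and the rest of the structure stays the same. The nearest measured change is a step that the two limits leave unreadable from compound 1 to compound 3 and it concerns the same hydroxymethyl group. Also relevant are a step that the two limits leave unreadable from compound 1 to compound 2 and a step that the two limits leave unreadable from compound 2 to compound 3 as further changes in that part of the structure. None of these has a readable size, so none offers a direction. On the evidence of a step that the two limits leave unreadable from compound 1 to compound 3 no step beyond the scatter is expected in this assay in either direction. The expected outcome is an at least 1.2-fold lower number from compound 3 to compound 4 (0.09 log units; that floor lies within the scatter) in size. Compound 4 is estimated at about 20000 nM with an expected range from 8000 nM to 40000 nM. A limit is a likely outcome for compound 4 as well.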

Compound 4, half-maximal cytotoxic concentration: > 12500 nM
Compound 4: no number, only a limit; the forecaster's own chance of this, stated with the estimate: 75%; the middle value does not contradict the limit.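

In this assay, going by these compounds alone, compound 4 is reported only as a limit, as are compound 1, compound 2 and compound 3, so no step among them can be read. The compounds shown leave open what concentration of each is actually tolerated, and whether any of these group changes alters it.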